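Removing a Fluoro Group from the Sulfonyl Aryl Ring

A few compounds are considered here, and "the series" means these few. Any claim that something is new, unique, unknown or untested is made for them only; others in the source may bear on it.

Measured so far:
compound 1, `O=C(NCc1ccc(F)cc1)c1ccc(N2CCN(S(=O)(=O)c3ccccc3C(F)(F)F)CC2)nn1`, which in an ADME assay on microsomes from liver (Mus musculus), read by LC-MS, using NADPH, tested at 10 uM (a lower number here means that the liver removes a smaller share, a higher number that the liver removes a larger share of the compound in one pass), gives 0.66
compound 2, `Cc1ccc(F)cc1S(=O)(=O)N1CCN(c2ccc(C(=O)NCc3ccc(F)cc3)nn2)CC1`, which in this assay gives 0.47

Going by the values given here, compound 2 stands lowest of the two numbers in this assay; its only neighbour is compound 1, and the step a number 0.19 lower from compound 1 to compound 2 (beyond the scatter) lies beyond the scatter. Compound 3, `Cc1ccccc1S(=O)(=O)N1CCN(c2ccc(C(=O)NCc3ccc(F)cc3)nn2)CC1`, has not yet been measured. It differs from compound 2 by hydrogen in place of fluoro on an aromatic carbon. Among the compounds with values here, the one measured step, a number 0.19 lower from compound 1 to compound 2 (beyond the scatter), replaces the whole aryl group on the sulfonyl sulfur, so it does not isolate the fluoro; no measured step tests hydrogen in place of fluoro on its own. With so little to lean on, only a small change in this assay is expected, leaning upward if anywhere. Compound 3 is therefore estimated at 0.54, between 0.4 and 0.7, an expected step of a number 0.070 higher from compound 2 to compound 3 (within the scatter) that should stay within the scatter.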

Compound 3, hepatic extraction ratio: 0.7
Compound 3: middle estimate off by 0.16, on the low side; the range from low to high includes it.
By their numbers in this assay, from the lowest: compound 2; then compounds 1 and 3 (each within the scatter of the next).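

In this assay, the fluoro para to a methyl group turns out to matter a good deal for this ring: exchanging it for hydrogen gives a number 0.23 higher from compound 2 to compound 3 (beyond the scatter) and so cancels what the earlier aryl change seemed to gain. Methyl in place of trifluoromethyl on the same ring, without any fluoro on the ring, gives a number 0.040 higher from compound 1 to compound 3 (within the scatter) and so makes no clear difference, which means the fluoro rather than the methyl sets compound 2 apart from the other two. Nothing available here explains why a single fluoro has this effect.

Still open, as far as these compounds go, is whether a fluoro elsewhere on this ring would lower the number in the same way, or whether a chlorine or a methoxy group at this place would match it. Also open, from the compounds shown here alone, is whether the same fluoro would act alike on the ring carrying trifluoromethyl.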